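Adding an amino group to an inactive cinnamate ester

The source may hold more compounds than are shown below. What is called first, only, known or untested is meant among the compounds shown, and "the series" means these compounds.

Compound 1 `COc1ccc2oc(=O)cc(COC(=O)C=C(C)C)c2c1` gives > 10 ug/mL in a functional assay on B16 cells (Mus musculus) for inhibition; on this read-out lower numbers stand for stronger inhibition and higher numbers for weaker inhibition
Compound 2 `COc1cc2oc(=O)cc(COC(=O)/C=C/c3ccccc3)c2cc1OC` gives > 10 ug/mL in this assay
Compound 3 `COc1cc2oc(=O)cc(COC(=O)/C=C/c3cc(OC)c(OC)c(OC)c3)c2cc1OC` gives 6.74 ug/mL in this assay

Compound 2 stands at > 10 ug/mL, which is a limit and not a number. It is not alone there, as the results show (the limit of > 10 ug/mL in this assay, at which 2 of the 3 values shown sit). Only compound 3 gives a true number, 6.74 ug/mL.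

Compound 4 `COc1cc2oc(=O)cc(COC(=O)/C=C/c3ccc(N)cc3)c2cc1OC` is compound 2 with one change: amino in place of hydrogen on an aromatic carbon. In words, amino replaces hydrogen on an aromatic carbon, para to a large group. Going by the values given here, no measured pair shows this change directly, so any forecast is rough. Compound 3 reaches 6.74 ug/mL with its own changes on an aromatic ring, so a modest gain is expected rather than a large one. A result at the limit would be no surprise for compound 4. The expected step is small: an at least 1.2-fold lower number from compound 2 to compound 4 (0.09 log units; that floor lies within the scatter). For compound 4 the estimated value is 8 ug/mL, with an expected range from 3 ug/mL to 20 ug/mL.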

Compound 4, half-maximal inhibitory concentration: > 10 ug/mL
Compound 4 ended at the assay's limit (the forecaster's own chance of this, stated with the estimate: 55%); middle value at least 1.2-fold (0.09 log units) from the limit.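

In this assay compound 4 gives > 10 ug/mL as a limit and not a number. Going by these compounds alone, compound 2 also sits at a limit, so no step between compound 2 and compound 4 can be read. The compounds shown leave open whether amino in place of hydrogen changes inhibition at all.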